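Core swap and trifluoromethyl removal in a cytotoxicity series

A few compounds are considered here, and "the series" means these few. Any claim that something is new, unique, unknown or untested is made for them only; others in the source may bear on it.

Compound 1 `COc1ccc(Cn2cc3cc(C(=N)Nc4cccc(C(F)(F)F)c4)ncc3n2)cc1` and compound 2 `COc1ccc(Cn2cc3cc(C(=N)Nc4ccccc4)ncc3n2)cc1` share one core; compound 3 `Cn1ncc2cc(C(=N)Nc3cccc(C(F)(F)F)c3)ncc21` and compound 4 `Cn1ncc2cc(C(=N)Nc3ccccc3)ncc21` share another. The difference between the two cores is not broken down here. In a functional assay on MDA-MB-231 cells (Homo sapiens) for cytotoxicity, read by MTT assay, with a stated time of 72 h (a higher number here means a weaker inhibitor, a lower number a stronger inhibitor), compound 1 gives 15500 nM and compound 2 gives 1520 nM. The change hydrogen in place of trifluoromethyl on an aromatic carbon produced a 10-fold lower number from compound 1 to compound 2 (1.01 log units; beyond the scatter). For compound 3 only a limit is known: in this assay compound 3 gives > 50000 nM, which is the limit of the assay and not a number, as noted by the limit of > 50000 nM in this assay, at which 1 of the 3 values shown sits. Compound 4 is not yet measured in this assay. Among the measured compounds shown here, the change hydrogen in place of trifluoromethyl on an aromatic carbon is the same kind of change as the one from compound 1 to compound 2, with the two place descriptions matching word for word. Because the earlier step was a 10-fold lower number from compound 1 to compound 2 (1.01 log units; beyond the scatter), a step of similar direction is expected here, though the starting point for compound 3 is only a limit. The expected step is an at least 3.3-fold lower number from compound 3 to compound 4 (0.52 log units; beyond the scatter). Compound 4 is therefore estimated at 15000 nM in this assay, with a likely range from 4000 nM to 60000 nM.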

Compound 4, half-maximal inhibitory concentration: > 50000 nM
Compound 4: a limit, no number; the forecaster's own chance of this, stated with the estimate: 25%; middle value at least 3.3-fold (0.52 log units) away from the limit.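

In this assay compound 4 gives > 50000 nM as a limit of the assay and not a number. Among the compounds shown here, compound 3 also stands at a limit, so no step from compound 3 to compound 4 can be read: the limit of > 50000 nM in this assay, at which 2 of the 4 values shown sit. Still open, as far as these compounds go, is whether hydrogen in place of trifluoromethyl acts on the core of compound 3 as it does on the core of compound 1.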